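A few compounds are considered here, and "the series" means these few. Any claim that something is new, unique, unknown or untested is made for them only; others in the source may bear on it.

Measured so far:
- compound 1, `COc1ccc(-c2ccnc(Nc3ccc(Cl)cc3Cl)n2)cc1`: 23000 nM in a functional assay on HeLa cells (Homo sapiens) for antiproliferative activity, read by MTT assay; a higher number here means a weaker inhibitor, a lower number a stronger inhibitor
- compound 2, `O=[N+]([O-])c1ccc(Nc2nccc(-c3ccc(F)cc3)n2)cc1`: 3510 nM in this assay

Of the two numbers, compound 2 has the lower one; compound 1 lies above it, and the gap between them is beyond the scatter of this assay. On these two values compound 2 is therefore the stronger of the pair.

Compound 3, `O=[N+]([O-])c1ccc(Nc2nccc(-c3ccc(Br)cc3)n2)cc1`, shares the core of compound 2 and differs from it in one place: bromo in place of fluoro on an aromatic carbon. Among the measured compounds shown here, no measured pair shows this change on its own, so there is nothing in the data to fix the size of the step. The expectation is a small shift, toward a lower number if anything, with a 1.4-fold lower number from compound 2 to compound 3 (0.15 log units; within the scatter) expected to remain within the usual scatter. For compound 3 the estimate in this assay is 2500 nM, with a range from 800 nM to 8000 nM.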

Compound 3, half-maximal inhibitory concentration: 25700 nM
Estimate against measurement, compound 3: 10-fold (1.01 log units) below, outside the stated range (above it).
By their numbers in this assay, from the lowest: compound 2; then compounds 1 and 3 (each within the scatter of the next).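

The 4-fluorophenyl to 4-bromophenyl change gives the series its first step at a single place, and in this assay it reads a 7.3-fold higher number from compound 2 to compound 3 (0.86 log units; beyond the scatter). This position, on an aromatic carbon para to a large group, is therefore not indifferent to which halogen it carries: one heavy atom replaced by one heavy atom, with no change in the counted hydrogen-bond donors, acceptors or net charge, moves the number beyond the scatter. No measurement at hand accounts for the direction or size of this step.

As far as these compounds go, whether the step tracks the halogen alone remains open, since chloro or iodo at this position would show whether the values change gradually or abruptly. Also open, from the compounds shown here alone, is whether the same exchange gives a step of similar size when the nitro group of the shared core is replaced by an amine.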